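Unbound fraction in chlorophenyl amides

The compounds below may be only part of what the source reports. "The series", "measured", "known", "first", "only" and "open" are said of these compounds alone.

compound 1 `Cn1cnc(S(=O)(=O)N2C[C@@H]3[C@H](C2)[C@@]3(CNC(=O)c2cc(Cl)cc(Cl)c2)CC2CC2)c1` gives 0.02
compound 2 `Cn1cnc(S(=O)(=O)N2C[C@@H]3[C@H](C2)[C@@]3(CNC(=O)c2c(Cl)cccc2Cl)CC2CC2)c1` gives 0.08

In an ADME assay on a cell-free system (plasma, Homo sapiens) for protein binding (a lower number here means a smaller unbound share, a higher number a larger unbound share of the compound), compound 2 stands highest of the two measured compounds at 0.08 and compound 1 lies lower. Compound 3 `Cn1cnc(S(=O)(=O)N2C[C@@H]3[C@H](C2)[C@@]3(CNC(=O)c2ccc(Cl)cc2)CC2CC2)c1` has not been measured. The change 4-chlorophenyl in place of 2,6-dichlorophenyl on a carbonyl carbon puts 4-chlorophenyl in place of 2,6-dichlorophenyl on a carbonyl carbon. Going by the values given here, the one measured step at that place is a 4.0-fold higher number from compound 1 to compound 2 (0.60 log units; beyond the scatter) and it holds no 4-chlorophenyl, so it guides only loosely. A step to a lower number is expected a 1.6-fold lower number from compound 2 to compound 3 (0.20 log units; within the scatter) and probably stays within the scatter. For compound 3 the estimated value is 0.05 (range 0.025 to 0.1) in this assay as measured so far.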

Compound 3, unbound fraction: 0.03
For compound 3 the middle estimate is 1.7-fold (0.22 log units) above the measured one, within the range that was stated.
By their numbers in this assay, from the lowest: compounds 1 and 3 (each within the scatter of the next); then compound 2.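

4-chlorophenyl in place of 2,6-dichlorophenyl on a carbonyl carbon gives a 2.7-fold lower number from compound 2 to compound 3 (0.43 log units; beyond the scatter) in this assay and does not keep the larger unbound share of compound 2. In place of 3,5-dichlorophenyl it gives a 1.5-fold higher number from compound 1 to compound 3 (0.18 log units; within the scatter) so these two groups are not told apart here, and among the three compounds only 2,6-dichlorophenyl stands clear of the others. Nothing available explains this difference.

Still open, from the compounds shown here alone, is whether 2-chlorophenyl at this place would keep the larger unbound share of compound 2, and how an aryl group carrying a carboxylic acid or an amine would read in this assay on the shared core.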